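The source may report more compounds than this note shows. Statements on the series, on what has been measured and on what is new or still open speak of the compounds shown alone.

Three hydrazide compounds built on a shared core were measured in a functional assay on MCF7 cells (Homo sapiens) for inhibition, read by sulforhodamine B assay, with a stated time of 48 h; on this read-out lower numbers stand for stronger inhibition of growth and higher numbers for weaker inhibition of growth. Compound 1 `O=C(NNC(=O)c1ccc2[nH]c(-c3ccc([N+](=O)[O-])o3)nc2c1)c1ccccc1` gives 62.5 ug/mL in this assay. Compound 3 `O=CNNC(=O)c1ccc2[nH]c(-c3ccc([N+](=O)[O-])o3)nc2c1`, which keeps the same core but ends in a plain formyl group, gives 62.5 ug/mL. Compound 2 `COc1cc(C(=O)NNC(=O)c2ccc3[nH]c(-c4ccc([N+](=O)[O-])s4)nc3c2)cc(OC)c1OC` carries a different ring on the core and a trimethoxyphenyl group at the far end; in this assay compound 2 gives 31.3 ug/mL. Among these three numbers compound 1 stands level with compound 3, the two being the highest, with compound 2 the furthest away yet still within the scatter. Exchanging the end group did nothing here: no change at the digits printed from compound 1 to compound 3 (within the scatter). Compound 4 `O=C(NNC(=O)c1ccc2[nH]c(-c3ccc([N+](=O)[O-])o3)nc2c1)c1cccc(Oc2ccccc2)c1` is not yet measured and differs from compound 1 thus: phenoxy in place of hydrogen on an aromatic carbon. For the measured compounds named here, the one measured step at this end of the molecule, hydrogen in place of phenyl, did not move the number, and the gap between compound 1 and compound 2 is also within the scatter. Compound 4 is therefore expected to sit close to compound 1, because no change at the digits printed from compound 1 to compound 3 (within the scatter) shows this end accepting very different groups without effect, so a step of no change at the digits printed from compound 1 to compound 4 (within the scatter) is expected. Compound 4 is estimated at 62.5 ug/mL, in the range 31 ug/mL to 125 ug/mL.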

Compound 4, concentration for 50% growth inhibition: > 7.8 ug/mL
Compound 4 gave a limit, no number (the forecaster's own chance of this, stated with the estimate: 10%); the middle value lies beyond the limit too.
By their numbers in this assay, from the lowest: compounds 2, 1 and 3 (each within the scatter of the next).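

In this assay, for the compounds shown here, compound 4 gives > 7.8 ug/mL, which is a limit and not a number, so no step from compound 1 to compound 4 can be read. The compounds shown leave open whether phenoxy in place of hydrogen on an aromatic carbon changes growth inhibition at all.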